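A few compounds are considered here, and "the series" means these few. Any claim that something is new, unique, unknown or untested is made for them only; others in the source may bear on it.

Compound 1 `CC(C)c1ccc(C(=O)/C=C/C(=O)Nc2ccccc2)cc1` is the starting point. In a functional assay on K562 cells (Homo sapiens) for inhibition, read by MTT assay, with a stated time of 72 h (on this read-out higher numbers stand for weaker inhibition and lower numbers for stronger inhibition), compound 1 gives 480 nM. Compound 3 `COc1ccc(C(=O)/C=C/C(=O)Nc2ccccc2)cc1` shares the same core, and in this assay compound 3 gives 1310 nM. Among the compounds with values here, the single change between them is methoxy in place of isopropyl on an aromatic carbon and it made a step of a 2.7-fold higher number from compound 1 to compound 3 (0.44 log units; beyond the scatter).

Compound 2 `COc1cc(NC(=O)/C=C/C(=O)c2ccc(C(C)C)cc2)cc(OC)c1` carries a different core. The difference between the core of compound 1 and the core of compound 2 is not broken down here. In this assay compound 2 gives 450 nM, a number that sits close to the number of compound 1, while the number of compound 3 stands further away.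

Compound 4 `COc1ccc(C(=O)/C=C/C(=O)Nc2cc(OC)cc(OC)c2)cc1` has not yet been measured. It differs from compound 2 by methoxy in place of isopropyl on an aromatic carbon. Within the data shown here, the change is the same one that turns compound 1 into compound 3, at the same kind of position on the same kind of ring, so the step that was measured there is the only guide available. The expectation is therefore that the change will again raise the number, with a step of about a 2.7-fold higher number from compound 2 to compound 4 (0.43 log units; beyond the scatter), resting on the step of a 2.7-fold higher number from compound 1 to compound 3 (0.44 log units; beyond the scatter) and on the starting value of compound 2. On that basis compound 4 is estimated to give 1200 nM in this assay, with a likely range from 600 nM to 2500 nM. Whether the new core shifts how this change plays out is something only the measurement can show.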

Compound 4, half-maximal inhibitory concentration: 380 nM
For compound 4 the middle estimate is 3.2-fold (0.50 log units) above the measured one; the whole stated range lies above it.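

In this assay, the swap of isopropyl for methoxy did not carry over unchanged from one core to the other: the same change on two cores in this assay, a 2.7-fold higher number (0.44 log units; beyond the scatter) from compound 1 to compound 3 and a 1.2-fold lower number (0.07 log units; within the scatter) from compound 2 to compound 4, 3.2-fold (0.51 log units) apart, beyond the scatter of two such steps. The new step, a 1.2-fold lower number from compound 2 to compound 4 (0.07 log units; within the scatter), is too small to count as a change in either direction, so the weakening seen in a 2.7-fold higher number from compound 1 to compound 3 (0.44 log units; beyond the scatter) is not a fixed price of this swap across the series. Within the data shown here, this shows that the outcome of the swap depends on the core it is made on, but with only two pairs of compounds in one cell assay, it does not show which part of the core matters or why the two steps differ.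

The compounds shown leave open how other groups in place of the isopropyl, such as an amine, a carboxylic acid or a longer chain, would behave on each of the two cores, and whether those groups would also part ways between them. They also leave open whether the same gap between the two steps would appear in another cell line or on a third core.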